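The source may hold more compounds than are shown below. What is called first, only, known or untested is meant among the compounds shown, and "the series" means these compounds.

Three compounds have been measured in an ADME assay on MDBK cells (Bos taurus) for cytotoxicity, read by MTT assay, with a stated time of 96 h; a higher number here means that more compound is tolerated, a lower number that less compound is tolerated:
compound 1, `CN1CCN(CC(=O)Nc2ccc(-c3nc4cc(Cl)c(Cl)cc4[nH]3)cc2)CC1`, 90000 nM.
compound 2, `Cn1c(-c2ccc([N+](=O)[O-])cc2)nc2cc(C(F)(F)F)ccc21`, > 100000 nM.
compound 3, `COc1ccc(-c2nc3cc([N+](=O)[O-])ccc3[nH]2)c(OC)c1OC`, > 100000 nM.

The value of compound 3 is a limit of this assay, not a number. The value of compound 2 is likewise a limit. Compound 1 is the only one of the three with a measured number, and it stands close to the limit of > 100000 nM in this assay, at which 2 of the 3 values shown sit. Compound 2 therefore sits at the top of what this assay can report, where nothing more can be said than that a high concentration is tolerated.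

Compound 4, `CCN(CC)CC(=O)Nc1ccc(-c2nc3cc(C(F)(F)F)ccc3n2C)cc1`, has still to be measured in this assay. It differs from compound 2 in one place: (((diethylamino)methyl)carbonyl)amino in place of nitro on an aromatic carbon. Going by the values given here, compound 1, the one compound with a measured number, gives 90000 nM, and a value in the same region is expected for compound 4. The expected step is an at least 1.1-fold lower number from compound 2 to compound 4 (0.04 log units; that floor lies within the scatter), which is within the scatter. For compound 4 the estimated value is 90000 nM, with a range from 40000 nM to 200000 nM, and a fair chance that only a limit is reported again.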

Compound 4, half-maximal cytotoxic concentration: 57000 nM
For compound 4 the middle estimate is 1.6-fold (0.20 log units) above the measured one, within the range that was stated.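

In this assay, going by these compounds alone, the exchange of nitro for (((diethylamino)methyl)carbonyl)amino, on an aromatic carbon para to a large group, gives an at least 1.7-fold lower number from compound 2 to compound 4 (0.24 log units; that floor lies within the scatter) as the first reading of this change at this position. That floor lies within the usual scatter, so the change is not shown to lower the tolerated concentration, yet compound 4 gives a real number where compound 2 gave only a limit. The true step may be larger, and its size stays unknown because compound 2 sits at the top of the scale: the limit of > 100000 nM in this assay, at which 2 of the 4 values shown sit.

From the compounds shown here alone, it stays open how much of this step belongs to the amide link and how much to the diethylamino end, which a plain amine or an acetylamino group at this place could separate. Going by these compounds, how a carboxylic acid or a longer chain would read here is also open.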